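The source may hold more compounds than are shown below. What is called first, only, known or untested is meant among the compounds shown, and "the series" means these compounds.

Measured so far in a functional assay on NCI-H23 cells (Homo sapiens) for inhibition, read by colorimetric assay and sulforhodamine B assay, with a stated time of 48 h; a higher number here means a weaker inhibitor of growth, a lower number a stronger inhibitor of growth:
compound 1 `CCCCCCCCCCCC[C@@H](O)[C@H]1CC[C@H]([C@H](O)CCCCCCCCCCNC(=O)c2ccco2)O1` – 12900 nM
compound 2 `CCCCCCCCCCCC[C@@H](O)[C@H]1CC[C@H]([C@H](O)CCCCCCCCCCNC(=O)c2ccoc2)O1` – 3020 nM

Compound 2 holds the lower of the two numbers in this assay and stands ahead of compound 1 by more than the scatter. The next compound is compound 3 `CCCCCCCCCCCC[C@@H](O)[C@H]1CC[C@H]([C@H](O)CCCCCCCCCCNC(=O)c2cncs2)O1` and its change from compound 2 is 1,3-thiazol-5-yl in place of furan-3-yl on a carbonyl carbon with the rest of the structure untouched. Among the compounds with values here, one measured step bears on this: a 4.3-fold lower number from compound 1 to compound 2 (0.63 log units; beyond the scatter) is a swap at the same place on the carbonyl carbon, and it is modest. No 1,3-thiazol-5-yl amide has been measured yet, so the data give no direction. The estimated step is a 1.3-fold higher number from compound 2 to compound 3 (0.12 log units; within the scatter) and no move beyond the scatter is expected. In this assay compound 3 is expected at 4000 nM with an estimated range from 1500 nM to 12000 nM overall.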

Compound 3, concentration for 50% growth inhibition: 4790 nM
The estimate for compound 3 lay 1.2-fold (0.08 log units) below the measured number; the range from low to high includes it.
By their numbers in this assay, from the lowest: compounds 2 and 3 (each within the scatter of the next); then compound 1.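

In this assay the 1,3-thiazol-5-yl amide shows a 1.6-fold higher number from compound 2 to compound 3 (0.20 log units; within the scatter), so a five-membered aromatic ring with 2 hetero atoms, nitrogen and sulfur, on this carbonyl carbon cannot be separated from furan-3-yl. Against furan-2-yl the same group shows a 2.7-fold lower number from compound 1 to compound 3 (0.43 log units; beyond the scatter), so compound 1 now stands apart from both other amides, while the ring in compound 2 and compound 3 can carry different hetero atoms without a step beyond the scatter. Nothing in hand bears on the reason for either step.

Still open, as far as these compounds go, is how a phenyl or pyridin-3-yl group on the same carbonyl carbon would read in this assay. Also open, from the compounds shown here alone, is whether a shorter or longer chain leading to the amide nitrogen would keep the separation of compound 1 from compound 2 and compound 3.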